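This account rests on a few compounds, and the source may have more. Where it says the series, first, only, none or still open, it means among the compounds named here.

The measured compounds:
Compound 1, `CCCn1ccc2cc(/C(C)=C/C(=O)Nc3ccccc3OCCCC(=O)O)ccc21`, gives 190 nM in an assay on Prostate gland for inhibition of steroid 5-alpha-reductase (Rattus norvegicus); a higher number here means a weaker inhibitor, a lower number a stronger inhibitor.
Compound 2, `CCCCc1ccc(Cn2ccc3cc(/C(C)=C/C(=O)Nc4ccccc4OCCCC(=O)O)ccc32)cc1`, gives 100 nM.
Compound 3, `CCCCCC(c1ccccc1)n1ccc2cc(/C(C)=C/C(=O)Nc3ccccc3OCCCC(=O)O)ccc21`, gives 25 nM.

Compound 3 has the lowest number of the three, and both a 7.6-fold lower number from compound 1 to compound 3 (0.88 log units; beyond the scatter) and a 4.0-fold lower number from compound 2 to compound 3 (0.60 log units; beyond the scatter) lie beyond the scatter, so it is the strongest inhibitor among them in this assay. Compound 4, `C/C(=C\C(=O)Nc1ccccc1OCCCC(=O)O)c1ccc2c(ccn2C(c2ccccc2)c2ccncc2)c1`, differs from compound 3 by pyridin-4-yl in place of pentyl on a saturated chain carbon bound to an aromatic carbon and an aromatic nitrogen. Going by the values given here, no measured step alters exactly this place in this way. The nearest guides are a 7.6-fold lower number from compound 1 to compound 3 (0.88 log units; beyond the scatter) and a 4.0-fold lower number from compound 2 to compound 3 (0.60 log units; beyond the scatter), both modest changes of the group on the aromatic nitrogen. On that basis the expected step of a 2.0-fold higher number from compound 3 to compound 4 (0.30 log units; within the scatter) is small, with a slightly higher number considered somewhat more likely. Compound 4 is therefore estimated at 50 nM, within a range from 15 nM to 170 nM.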

Compound 4, half-maximal inhibitory concentration: 26 nM
Beside the measured number, compound 4's estimate is 1.9-fold (0.28 log units) above it; low and high end bracket the measured number.
By their numbers in this assay, from the lowest: compounds 3 and 4 (each within the scatter of the next); then compounds 2 and 1 (each within the scatter of the next).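

Putting pyridin-4-yl in place of pentyl on the saturated chain carbon bound to an aromatic carbon and an aromatic nitrogen gives a 1.0-fold higher number from compound 3 to compound 4 (0.02 log units; within the scatter) in this assay. The earlier steps shown here changed the whole group on the aromatic nitrogen, whereas here a ring with a hydrogen-bond acceptor replaces an open chain on that carbon and the two numbers cannot be told apart. Nothing available offers a reason for this match. From the compounds shown here alone, what a plain phenyl, an amine or a carboxylic acid in that place would give stays open.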